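Compound 2 to compound 3: iodo replaced by methyl

The source may hold more compounds than are shown below. What is called first, only, known or untested is meant among the compounds shown, and "the series" means these compounds.

The shared core is that of compound 1 `CC(C)n1ncc2c(C(=O)Nc3ccccc3)cccc21`. In a functional assay on MGC-803 cells (Homo sapiens) for inhibition, read by MTT assay, with a stated time of 72 h (a lower number here means a stronger inhibitor, a higher number a weaker inhibitor), compound 1 gives 38500 nM. Compound 2 `CC(C)n1ncc2c(C(=O)NCc3cn(-c4ccc(I)cc4)nn3)cccc21` carries a 4-iodophenyl group on a longer side chain. In this assay compound 2 reaches only > 40000 nM, which is a limit of the assay and not a number; (the limit of > 40000 nM in this assay, at which 1 of the 2 values shown sits). Among the measured compounds shown here, compound 2 and compound 1 differ in more than one place, so their two values are simply set side by side with no step drawn between them. Compound 3 `Cc1ccc(-n2cc(CNC(=O)c3cccc4c3cnn4C(C)C)nn2)cc1` differs from compound 2 by methyl in place of iodo on an aromatic carbon; the same difference, cut one bond further out, reads 4-iodophenyl to 4-methylphenyl. For the measured compounds named here, no step between measured compounds is available, so no change beyond the usual scatter is expected in this assay. The expected step that the limit leaves unreadable from compound 2 to compound 3 stays within that scatter. Compound 3 is estimated at 45000 nM in this assay, with a range from 15000 nM to 150000 nM.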

Compound 3, half-maximal inhibitory concentration: > 40000 nM
Compound 3: only a limit was reported; the forecaster's own chance of this, stated with the estimate: 65%; the middle value is on the limit's open side.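

Compound 2 and compound 3 each give only a limit of the assay and not a number, so no step can be read between them: the limit of > 40000 nM in this assay, at which 2 of the 3 values shown sit.

From the compounds shown here alone, whether 4-methylphenyl in place of 4-iodophenyl changes the read-out at all remains open.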